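Extending a Side Chain Toward an Ester Terminus

The source may report more compounds than this note shows. Statements on the series, on what has been measured and on what is new or still open speak of the compounds shown alone.

Of the compounds shown here, three built on one shared core have been tested in an assay on isolated protein for inhibition of leukotriene B4 receptor 1 (Homo sapiens), tested at 10 uM; a lower number here means less inhibition, a higher number more inhibition at the concentration tested (going by the name of the read-out). Compound 1, `CC(=O)c1cc(CO)c(OCCCCCCC#N)cc1O`, carries a chain ending in a nitrile; in this assay compound 1 gives 40%. Compound 2, `CCc1cc(C(C)=O)c(O)cc1OCCCCCC(C)(C)C(=O)O`, carries a longer chain ending in a carboxylic acid, and in this assay compound 2 gives 104%. Compound 3, `C=CCc1cc(C(C)=O)c(O)cc1OCCCC`, carries a plain butoxy chain; in this assay compound 3 gives 32%. On these numbers compound 3 and compound 1 sit together at the low end, their gap within the scatter, while compound 2 stands far above both, beyond the scatter.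

Compound 4, `C=CCc1cc(C(C)=O)c(O)cc1OCCCCCC(=O)OC`, has not yet been measured. It differs from compound 3 in one place:

(methoxycarbonyl)methyl in place of hydrogen on a saturated chain carbon, four bonds along the chain from an oxygen on an aromatic ring

Among the compounds with values here, no measured pair shows this exact step, so its size has to be judged from the whole set. Compound 2 shows that a long chain ending in an acid goes with high inhibition, because compound 2 gives 104%, whereas the short chain of compound 3 goes with a low number. An ester is not an acid, so a rise is expected but a moderate one, a number 23 percentage points higher from compound 3 to compound 4 (beyond the scatter). Compound 4 is estimated at 55%, with a range from 30% to 85%.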

Compound 4, a percentage reported as inhibition, at one concentration (the size of the read-out at that concentration, not a potency): 106%
For compound 4 the middle estimate is 51 percentage points below the measured one; measured number above the stated range.
By their numbers in this assay, from the lowest: compounds 3 and 1 (each within the scatter of the next); then compounds 2 and 4 (each within the scatter of the next).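

Within the data shown here, replacing hydrogen with (methoxycarbonyl)methyl on a saturated chain carbon, four bonds along the chain from an oxygen on an aromatic ring, gives in this assay a number 74 percentage points higher from compound 3 to compound 4 (beyond the scatter), the first direct reading of a change at this position. The outer part of the chain therefore matters a great deal in this assay: a single added group of 5 heavy atoms, with no ring and no net charge, takes the short-chain compound 3 from the low end of the set to a high level of inhibition. Among these compounds, nothing available here accounts for why one change moves the number so far.

On these data alone, what remains open is whether the rise belongs to the methyl ester or simply to the longer chain, a question that a plain alkyl chain of the same length, or the same chain ending in a carboxylic acid or an amide, could help separate. As far as these compounds go, these numbers also come from a single concentration, so how much compound 3 and compound 4 differ in potency remains unknown.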